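The source may report more compounds than this note shows. Statements on the series, on what has been measured and on what is new or still open speak of the compounds shown alone.

Cytotoxicity in the series is followed in an ADME assay on Raji cells (Homo sapiens) for cytotoxicity, read by CellTiter-Glo and resazurin assay, with a stated time of 72 h; on this read-out lower numbers stand for an effect already at smaller amounts and higher numbers for an effect only at larger amounts of compound. Compound 1 `CC(C)N(Cc1cccc(OCCCCCC(=O)O)c1)C(=O)c1ccc(-c2cccc(Oc3ccccc3)c2)cc1` carries a phenoxy on the biaryl; in this assay compound 1 reaches only the assay limit, > 18700 nM. Compound 2 `CC(C)N(Cc1cccc(OCCCCCC(=O)O)c1)C(=O)c1ccc(-c2ccsc2)cc1` bears thiophen-3-yl on the core; in this assay compound 2 again gives only a limit, > 26000 nM. Compound 3 `CCOc1cccc(-c2ccc(C(=O)N(Cc3cccc(OCCCCCC(=O)O)c3)C(C)C)cc2)c1`, with 3-ethoxyphenyl, stands at a limit as well, > 20800 nM. Since every value shown is a limit, the two steps onto compound 3, a step that the two limits leave unreadable from compound 1 to compound 3 and a step that the two limits leave unreadable from compound 2 to compound 3, have no readable size, and compound 3 cannot be placed relative to compound 1 or compound 2 beyond the fact that all three sit at their respective limits (the limit of > 18700 nM in this assay, at which 1 of the 3 values shown sits), (the limit of > 20800 nM in this assay, at which 1 of the 3 values shown sits), (the limit of > 26000 nM in this assay, at which 1 of the 3 values shown sits).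

Compound 4 `CC(C)N(Cc1cccc(OCCCCCC(=O)O)c1)C(=O)c1ccc(-c2cccc(Cl)c2)cc1` differs from compound 3 by chloro in place of ethoxy on an aromatic carbon. Among the compounds with values here, no measured step bears on this change in a readable way; the only information is that three distinct aryl substituents all leave cytotoxicity at or beyond the assay limit. The step that the limit leaves unreadable from compound 3 to compound 4 is therefore expected to be none beyond the scatter, with compound 4 most likely reported as a limit again. Compound 4 is estimated at 30000 nM in this assay, with a range of 10000 nM to 100000 nM.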

Compound 4, half-maximal effective concentration: > 21900 nM
Compound 4 ended at the assay's limit (the forecaster's own chance of this, stated with the estimate: 85%); the middle value does not contradict the limit.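

With compound 4 also at a limit, the steps onto it from compound 1, compound 2 and compound 3 cannot be read, so no size can be given for any of them. The compounds shown leave open whether any substituent on the shared core yields a measurable value in this assay.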